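Methyl removal on the fused core: compound 2 to compound 3

The compounds below may be only part of what the source reports. "The series", "measured", "known", "first", "only" and "open" are said of these compounds alone.

Measured so far:
compound 1, `Cc1ccccc1CNC(=O)n1c(N)nc2ccccc21`, 68.4 nM
compound 2, `Cc1nc2ccccc2n1C(=O)NCCCCc1ccccc1`, 1 nM

Both numbers come from an assay on HEK293 cells for inhibition of acid ceramidase (Homo sapiens), read by fluorescence, with stated times of 30 min and 1 h; a higher number here means a weaker inhibitor, a lower number a stronger inhibitor. Compound 2 gives 1 nM and stands lowest of the two, so it is the stronger inhibitor here; compound 1 gives 68.4 nM, a gap well beyond the usual scatter. Within the data shown here, compound 1 and compound 2 differ in more than one place, so no single step is drawn between them and the two values are taken only as they stand.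

Compound 3, `O=C(NCCCCc1ccccc1)n1cnc2ccccc21`, is not yet measured in this assay. Its difference from compound 2 is hydrogen in place of methyl on an aromatic carbon. Among the measured compounds shown here, nothing among the measured compounds isolates this methyl; no step of this kind has been measured, so the expectation rests only on the pair above. Taking the methyl away is expected to cost a small to moderate amount, with the step of a 3.0-fold higher number from compound 2 to compound 3 (0.48 log units; beyond the scatter) as the estimate, possibly within scatter. Compound 3 is therefore estimated at 3 nM, with a range from 0.8 nM to 12 nM.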

Compound 3, half-maximal inhibitory concentration in the acid ceramidase assay: 2.5 nM
For compound 3 the middle estimate is 1.2-fold (0.08 log units) above the measured one; measured number inside the range.
By their numbers in the acid ceramidase assay, from the lowest: compound 2; then compound 3; then compound 1.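

In the acid ceramidase assay, hydrogen in place of methyl on the aromatic carbon between two ring nitrogen atoms gives a 2.5-fold higher number from compound 2 to compound 3 (0.40 log units; beyond the scatter), so this position accepts the loss of the methyl at a modest cost in inhibition. In a physicochemical assay for metabolic stability, read by HPLC, at pH 4.5, tested at 10 uM (on this read-out lower numbers stand for a shorter-lived compound and higher numbers for a longer-lived compound), compound 2 gives 0.133 h, and the same change gives an at least 15-fold higher number from compound 2 to compound 3 (1.17 log units; beyond the scatter), a large step set against the modest one, so this single position moves the two read-outs by very different amounts. In the physicochemical assay, compound 3 gives > 2 h, which is a limit of the assay and not a number.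

As far as these compounds go, whether an ethyl or a methoxy group on this aromatic carbon would keep the longer half-life of compound 3 while matching the inhibition of compound 2 stays open. The full size of the half-life step also stays open beyond the limit, and this step is shown for only one side chain, so its behaviour with a shorter or longer chain remains unknown.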